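Chloro to bromo at the assay limit

A few compounds are considered here, and "the series" means these few. Any claim that something is new, unique, unknown or untested is made for them only; others in the source may bear on it.

Measured in a functional assay on MCF7 cells (Homo sapiens) for inhibition, read by MTT assay, with a stated time of 72 h; a higher number here means a weaker inhibitor, a lower number a stronger inhibitor:
- Compound 1 `O=C1N/C(=N/c2nc3cc(-c4ccc(Cl)cc4)sc3s2)S/C1=C/c1ccc(F)cc1`: 21000 nM
- Compound 2 `O=C1N/C(=N/c2nc3cc(-c4ccc(Cl)cc4)sc3s2)S/C1=C/c1ccc(Cl)cc1`: > 50000 nM, a limit

Compound 2 gives no number and stands at the limit of > 50000 nM in this assay, at which 1 of the 2 values shown sits. Compound 3 `O=C1N/C(=N/c2nc3cc(-c4ccc(Br)cc4)sc3s2)S/C1=C/c1ccc(Cl)cc1` differs from it by bromo in place of chloro on an aromatic carbon. Going by the values given here, the only measured step that bears on this is an at least 2.3-fold higher number from compound 1 to compound 2 (0.37 log units; beyond the scatter), with chloro in place of fluoro, a different halogen exchange. With compound 2 at a limit and that step only an indirect guide, no step beyond the scatter is expected in this assay. The expected change is a number no higher from compound 2 to compound 3 (the limit leaves the size open). For compound 3 the estimated value is 50000 nM, with an expected range of 20000 nM to 120000 nM.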

Compound 3, half-maximal inhibitory concentration: 11000 nM
Compound 3: the middle estimate sits 4.5-fold (0.66 log units) above what was measured; the whole stated range lies above it.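

In this assay, 4-chlorophenyl to 4-bromophenyl gives an at least 4.5-fold lower number from compound 2 to compound 3 (0.65 log units; beyond the scatter), so this place, para to a large group, responds to a halogen exchange. The exchange at the other halogen gave an at least 2.3-fold higher number from compound 1 to compound 2 (0.37 log units; beyond the scatter), so the two places do not share a direction of change. Compound 2 is a limit and not a number, which leaves the true size of the new step open: the limit of > 50000 nM in this assay, at which 1 of the 3 values shown sits.

Still open, going by these compounds, is whether iodo or fluoro at this place would continue the trend. A methoxy group or an amine here would show whether the gain is confined to halogens.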